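This account rests on a few compounds, and the source may have more. Where it says the series, first, only, none or still open, it means among the compounds named here.

Working notes on the series in an ADME assay on NIH3T3 cells (Mus musculus) for cytotoxicity, read by XTT assay, with a stated time of 24 h; on this read-out higher numbers stand for weaker inhibition and lower numbers for stronger inhibition. Compound 1 `Cc1ccc(-c2csc(N3N=C(c4ccc(C)s4)CC3c3ccc(F)cc3)n2)cc1` is the reference point. For compound 1 the read-out in this assay is a limit of the assay and not a number, > 500 ug/mL. Compound 2 `Fc1ccc(C2CC(c3ccc(Cl)s3)=NN2c2nc(-c3ccc(Br)cc3)cs2)cc1` carries the other measured value. For compound 2 this assay likewise reports only a limit, > 500 ug/mL. Among the measured compounds shown here, both measured values therefore sit at the limit of > 500 ug/mL in this assay, at which 2 of the 2 values shown sit, so compound 1 cannot be placed above or below any other measured member; no step between measured compounds is available, and nothing about the size of a change is known from the data.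

Compound 3 `COc1ccc(-c2csc(N3N=C(c4ccc(C)s4)CC3c3ccc(F)cc3)n2)cc1` is unmeasured. It differs from compound 1 by methoxy in place of methyl on an aromatic carbon. With both measured values at the limit, no step beyond the scatter is expected from compound 1 to compound 3 in this assay, a step that the limit leaves unreadable from compound 1 to compound 3. Compound 3 is estimated at 600 ug/mL, in the range 300 ug/mL to 2000 ug/mL, most likely again reported as a limit.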

Compound 3, half-maximal inhibitory concentration: 147 ug/mL
Compound 3: the middle estimate sits 4.1-fold (0.61 log units) above what was measured; measured number below the stated range.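

In this assay the change from 4-methylphenyl to 4-methoxyphenyl gives an at least 3.4-fold lower number from compound 1 to compound 3 (0.53 log units; beyond the scatter), so this position, on an aromatic carbon para to a large group, is not silent in this read-out. Compound 3 is the only member shown whose result is a number and not a limit, which gives the series its one firm value to compare against. As far as these compounds go, the true size of the step stays unknown, because its starting point is a limit and not a number: the limit of > 500 ug/mL in this assay, at which 2 of the 3 values shown sit.

From the compounds shown here alone, whether the lower number is particular to methoxy or also appears with other groups at this position, such as an amine, a hydroxyl or a longer ether chain, stays open. Also open, going by these compounds, is whether the same change would have a like effect on the rest of compound 2.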